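Cyclopropyl for furan-3-yl on the fused core

The source may report more compounds than this note shows. Statements on the series, on what has been measured and on what is new or still open speak of the compounds shown alone.

Compound 1 `CCc1cc2c(=O)[nH]c(-c3ccoc3)nc2s1` is the compound of this series with a single recorded number in an assay on CRE-SPAP cells for displacement of a labelled ligand from transmembrane domain-containing protein TMIGD3 (Homo sapiens), read by fluorescence, with a stated time of 1 h (a lower number here means a stronger inhibitor, a higher number a weaker inhibitor), where compound 1 gives 550 nM. The second measured compound, compound 2 `O=C(Nc1nc(C2CC2)cs1)c1ccoc1`, is built on a different frame and is the only other entry in this assay, where compound 2 gives 105 nM; 120 nM (2 entries); the repeat entries of compound 2 sit close together, as the evidence shows (the several entries of compound 2 in this assay, 105 nM; 120 nM (2 entries)). For the measured compounds named here, no pair of measured compounds differs in a single place, so no measured step exists here.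

The unmeasured compound 3 `CCc1cc2c(=O)[nH]c(C3CC3)nc2s1` differs from compound 1 in one place: cyclopropyl in place of furan-3-yl on an aromatic carbon. Going by the values given here, with no matched step measured, the size of the change is open; the working expectation is a step of modest size, leaning toward a weaker inhibitor, with a fair chance that it stays within the usual scatter. The step from compound 1 to compound 3 that this estimate means is a 1.5-fold higher number from compound 1 to compound 3 (0.16 log units; within the scatter). Compound 3 is therefore expected to give about 800 nM in this assay, in a range from 250 nM to 2500 nM.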

Compound 3, inhibition constant: 1820 nM
Compound 3: middle estimate off by 2.3-fold (0.36 log units), on the low side; the range from low to high includes it.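

In this assay, for the compounds shown here, replacing furan-3-yl with cyclopropyl on the aromatic carbon between two ring nitrogen atoms gives a 3.3-fold higher number from compound 1 to compound 3 (0.52 log units; beyond the scatter), the first matched step. This position on the shared core is therefore not indifferent to the group it carries, and on this core furan-3-yl gives the lower number of the two. The size of the step also stands out against the close agreement of repeat readings on the other frame, although those readings come from a single compound: the several entries of compound 2 in this assay, 105 nM; 120 nM (2 entries)

The change removes an aromatic five-membered ring and its oxygen and reduces the heavy-atom count in one move, so the step cannot be assigned to any one of these differences. Thiophen-3-yl and tetrahydrofuran-3-yl at the same position would help separate the roles of the ring oxygen and aromaticity, while the effect of an amine there remains open.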